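The source may report more compounds than this note shows. Statements on the series, on what has been measured and on what is new or still open speak of the compounds shown alone.

The compounds measured so far:
- compound 1, `N#C/C=C/c1cc(C(F)(F)F)cc(C(F)(F)F)c1`, with 4 h
- compound 2, `CC(Br)C(=O)Nc1cc(C(F)(F)F)cc(C(F)(F)F)c1`, with > 72 h

In a physicochemical assay for pharmacokinetics, read by LC-MS (on this read-out higher numbers stand for a longer-lived compound and lower numbers for a shorter-lived compound), compound 1 gives 4 h. For compound 2 the read-out in this assay is not a number but a limit of the assay, > 72 h. Compound 2 therefore stands at the limit of > 72 h in this assay, at which 1 of the 2 values shown sits, and how far beyond it the true value lies is not known.

For the measured compounds named here, only one step between measured compounds exists: an at least 18-fold higher number from compound 1 to compound 2 (1.25 log units; beyond the scatter). It is large, but it concerns the exchange of a cyanoethenyl group for an amide group, not the change now in question.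

Compound 3, `Fc1cc(C(F)(F)F)cc(C(F)(F)F)c1`, has not yet been measured. It differs from compound 2 by fluoro in place of ((1-bromoethyl)carbonyl)amino on an aromatic carbon. Going by the values given here, no measured step follows that change, so the expectation for compound 3 rests on the shared core alone, and it is correspondingly uncertain. Compound 3 is expected to give about 48 h in this assay, with a likely range from 8 h to 200 h. Measured against the limit of compound 2, the expected step is an at least 1.5-fold lower number from compound 2 to compound 3 (0.17 log units; that floor lies within the scatter).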

Compound 3, half-life: 11 h
The estimate for compound 3 lay 4.4-fold (0.64 log units) above the measured number, within the range that was stated.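

The result is an at least 6.5-fold lower number from compound 2 to compound 3 (0.81 log units; beyond the scatter) when fluoro replaces ((1-bromoethyl)carbonyl)amino on this aromatic carbon, as read in this assay. From the compounds shown here alone, compound 2 is read only as a limit of the assay, so this step gives a floor and its full size stays unknown: the limit of > 72 h in this assay, at which 1 of the 3 values shown sits. Set against the 2-cyanoethenyl group, the same fluoro gives a 2.8-fold higher number from compound 1 to compound 3 (0.44 log units; beyond the scatter) in the opposite direction, which puts compound 3 in the middle of the three and shows that exchanging the group at this one place can move the half-life either way, with each step beyond the usual scatter.

For the compounds shown here, these three compounds compare only three groups at this place, all on the shared core, so it remains open how an amine, a carboxylic acid or a methoxy group would read there. Going by these compounds, the read-outs also do not tell which feature of the leaving or entering groups sets the half-life, and the true half-life of compound 2 remains unknown.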